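This account rests on a few compounds, and the source may have more. Where it says the series, first, only, none or still open, it means among the compounds named here.

Compound 1 `COc1cc(C(=O)c2cn(-c3cccc(C)c3)cc2-c2ccc([N+](=O)[O-])cc2)cc(OC)c1OC`: 780 nM
Compound 2 `COc1cc(C(=O)c2cn(-c3cccc(C)c3)cc2-c2cccc(N)c2)cc(OC)c1OC`: 130 nM
Compound 3 `COc1cc(C(=O)c2cn(-c3ccc(F)cc3)cc2-c2ccc([N+](=O)[O-])cc2)cc(OC)c1OC`: 240 nM

These values come from a functional assay on MCF7 cells (Homo sapiens) for cytotoxicity, read by MTT assay, with a stated time of 96 h; a higher number here means a weaker inhibitor, a lower number a stronger inhibitor. Within this set the change from compound 1 to compound 2 is 3-aminophenyl in place of 4-nitrophenyl on an aromatic carbon; that change produced a 6.0-fold lower number from compound 1 to compound 2 (0.78 log units; beyond the scatter). The two cores differ by 4-fluorophenyl in place of 3-methylphenyl on an aromatic nitrogen, a change that gave a 3.3-fold lower number from compound 1 to compound 3 (0.51 log units; beyond the scatter). Compound 2 and compound 3 are within the scatter of each other, so nothing is said about their order.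

Compound 4 `COc1cc(C(=O)c2cn(-c3ccc(F)cc3)cc2-c2cccc(N)c2)cc(OC)c1OC` has not yet been measured in this assay. It differs from compound 3 by 3-aminophenyl in place of 4-nitrophenyl on an aromatic carbon. The place is the same kind of place as in the earlier change, but here the ring atom two ring bonds away bears a 4-fluorophenyl group where before it bore a 3-methylphenyl group, so this is the same kind of change, not the same change. Among the compounds with values here, for compound 4 a step of a 4.8-fold lower number from compound 3 to compound 4 (0.68 log units; beyond the scatter) is expected, which rests on the one earlier instance, a 6.0-fold lower number from compound 1 to compound 2 (0.78 log units; beyond the scatter), tempered for a single observation. Compound 4 is therefore estimated at 50 nM, expected between 15 nM and 160 nM.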

Compound 4, half-maximal inhibitory concentration: 53 nM
Beside the measured number, compound 4's estimate is 1.1-fold (0.03 log units) below it, within the range that was stated.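

In this assay the exchange of 4-nitrophenyl for 3-aminophenyl carries from one core to the other, and the step on the 4-fluorophenyl core, a 4.5-fold lower number from compound 3 to compound 4 (0.66 log units; beyond the scatter), agrees with the earlier one: the same change on two cores in this assay, a 6.0-fold lower number (0.78 log units; beyond the scatter) from compound 1 to compound 2 and a 4.5-fold lower number (0.66 log units; beyond the scatter) from compound 3 to compound 4, 1.3-fold (0.12 log units) apart, within the scatter of two such steps. The exchange of 3-methylphenyl for 4-fluorophenyl on the ring nitrogen also holds on the 3-aminophenyl core, with a 2.5-fold lower number from compound 2 to compound 4 (0.39 log units; beyond the scatter), and agrees with its earlier step: the same change on two cores in this assay, a 3.3-fold lower number (0.51 log units; beyond the scatter) from compound 1 to compound 3 and a 2.5-fold lower number (0.39 log units; beyond the scatter) from compound 2 to compound 4, 1.3-fold (0.12 log units) apart, within the scatter of two such steps. This is one pair of cores for each change, so the two changes combine consistently within these four compounds only, with no rule shown for other cores; 4-nitrophenyl and 3-aminophenyl differ in both the group and its place on the phenyl ring, and the step cannot be divided between the two.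

Still open, going by these compounds, is how 4-aminophenyl or 3-nitrophenyl would read on the same aromatic carbon, which would separate the group from its place. Also open, on these data alone, is whether an acetamide in place of the amine, or 4-chlorophenyl on the ring nitrogen, would follow the same steps.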